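The source may hold more compounds than are shown below. What is called first, only, known or untested is meant among the compounds shown, and "the series" means these compounds.

Compounds measured so far:

Compound 1, `N#CC1=C(N)Oc2c(N)cc3nc4ccccc4nc3c2C12C(=O)N(Cc1cnnn1-c1ccccc1Cl)c1ccccc12`. In a functional assay on HCT-116 cells (Homo sapiens) for antiproliferative activity, read by MTT assay, with a stated time of 48 h (a lower number here means a stronger inhibitor, a higher number a weaker inhibitor), compound 1 sits at a limit of the assay, > 50000 nM, not at a number.
Compound 2, `COc1ccccc1-n1nncc1CN1C(=O)C2(C(C#N)=C(N)Oc3c(N)cc4nc5ccccc5nc4c32)c2ccccc21`. In this assay compound 2 also sits at a limit, > 50000 nM.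
Compound 3, `CCc1cccc(C)c1-n1nncc1CN1C(=O)C2(C(C#N)=C(N)Oc3c(N)cc4nc5ccccc5nc4c32)c2ccccc21`. In this assay compound 3 likewise sits at a limit, > 50000 nM.

Compound 3 therefore stands where the other two stand: all three values are limits, as the limit of > 50000 nM in this assay, at which 3 of the 3 values shown sit, records. The steps among them cannot be read: a step that the two limits leave unreadable from compound 1 to compound 2, a step that the two limits leave unreadable from compound 1 to compound 3 and a step that the two limits leave unreadable from compound 2 to compound 3 are all left open by the limits.

Compound 4, `COc1cc(-n2nncc2CN2C(=O)C3(C(C#N)=C(N)Oc4c(N)cc5nc6ccccc6nc5c43)c3ccccc32)c(OC)cc1Cl`, differs from compound 3 in one place: 4-chloro-2,5-dimethoxyphenyl in place of 2-ethyl-6-methylphenyl on an aromatic nitrogen. The measured steps that bear on this change, the exchange of one aryl group for another on the same aromatic nitrogen, gave no readable size, so no direction beyond the scatter is expected from them. Compound 4 is expected to remain at the same limit, with an estimated step that the limit leaves unreadable from compound 3 to compound 4. The estimate for compound 4 in this assay is 60000 nM, within 20000 nM to 200000 nM.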

Compound 4, half-maximal inhibitory concentration: > 50000 nM
Compound 4 was reported as a limit; the forecaster's own chance of this, stated with the estimate: 85%; the middle value does not contradict the limit.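

In this assay, among the compounds shown here, compound 4 gives > 50000 nM, which is a limit, so no step between compound 4 and compound 1, compound 2 or compound 3 can be read. The compounds shown leave open whether these aryl groups on the aromatic nitrogen differ at all in antiproliferative activity, with every value resting at one limit: the limit of > 50000 nM in this assay, at which 4 of the 4 values shown sit.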